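The source may hold more compounds than are shown below. What is called first, only, known or untested is meant among the compounds shown, and "the series" means these compounds.

Compound 1 `CC(c1ccc(-c2ccccc2)c(F)c1)c1nnc2n1N=C(c1ccccc1)CS2` and compound 2 `COc1ccc2cc(C(C)c3nnc4n3N=C(c3ccc(Cl)cc3Cl)CS4)ccc2c1` share one core yet differ in several places at once, so their numbers can only be set side by side. In a functional assay on HCT-116 cells (Homo sapiens) for inhibition, read by sulforhodamine B assay, with a stated time of 72 h (on this read-out higher numbers stand for weaker inhibition and lower numbers for stronger inhibition), compound 1 gives 9700 nM. In this assay compound 2 gives 14000 nM, and the two numbers lie within the usual scatter of each other, so neither stands apart. Compound 3 `CC(c1ccc(-c2ccccc2)c(F)c1)c1nnc2n1N=C(c1ccc(Cl)cc1)CS2` keeps everything of compound 1 except one change: chloro in place of hydrogen on an aromatic carbon. Among the compounds with values here, no measured pair isolates this change; the step of a 1.4-fold lower number from compound 1 to compound 3 (0.14 log units; within the scatter) is expected to be small, if anything a slight gain, and not clearly beyond the scatter. Compound 3 is therefore expected to give 7000 nM, with a range from 3000 nM to 20000 nM.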

Compound 3, half-maximal inhibitory concentration: 7800 nM
The estimate for compound 3 lay 1.1-fold (0.05 log units) below the measured number; the range from low to high includes it.
By their numbers in this assay, from the lowest: compounds 3, 1 and 2 (each within the scatter of the next).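

Chloro in place of hydrogen now has a step of its own at this place, para to a large group: in this assay the change gives a 1.2-fold lower number from compound 1 to compound 3 (0.09 log units; within the scatter) and stays within the scatter. Phenyl to 4-chlorophenyl therefore shows no clear gain or loss here. No available measurement bears on why this step is so small.

On these data alone, whether an amine or a carboxylic acid at this place would move the number beyond the scatter stays open. So does whether chloro would give a similar step with different groups elsewhere on the shared core.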